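From Hydroxy to Acetoxy on Compound 2

A few compounds are considered here, and "the series" means these few. Any claim that something is new, unique, unknown or untested is made for them only; others in the source may bear on it.

Measured so far in a functional assay on A-427 cells (Homo sapiens) for cytotoxicity, read by colorimetric assay and MTT assay; on this read-out higher numbers stand for weaker inhibition and lower numbers for stronger inhibition:
- compound 1 `COc1cc(OC)c2cc(-c3ccc(O)cc3)c(O)nc2c1`: 10000 nM
- compound 2 `COc1cc(OC)c2cc(-c3ccc(O)cc3)c(=O)n(C)c2c1`: 10000 nM

In this assay compound 2 stands level with compound 1, and the two values lie within the usual scatter of each other. Neither value therefore separates the pair. Compound 3 `COc1cc(OC)c2cc(-c3ccc(OC(C)=O)cc3)c(=O)n(C)c2c1` has not yet been measured. It differs from compound 2 by one change, (acetyl in place of hydrogen on an oxygen on an aromatic ring), which turns hydroxy to acetoxy: acetyl in place of hydrogen on an oxygen on an aromatic ring. For the measured compounds named here, no step between measured compounds shows what such a change does. Going by the values given here, the only anchor is compound 2 at 10000 nM, so no step beyond the scatter is expected, with a slight lean toward stronger inhibition. The estimated change is a 1.3-fold lower number from compound 2 to compound 3 (0.10 log units; within the scatter). For compound 3 the expected value is 8000 nM, with an estimated range from 3000 nM to 15000 nM.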

Compound 3, half-maximal inhibitory concentration: 10000 nM
The estimate for compound 3 lay 1.3-fold (0.10 log units) below the measured number; the measured number falls inside the stated range.
By their numbers in this assay, from the lowest: compounds 1, 2 and 3 (each within the scatter of the next).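

In this assay, acetyl in place of hydrogen on an oxygen on an aromatic ring gives no change at the digits printed from compound 2 to compound 3 (within the scatter). For the compounds shown here, this is the first step read at this position, and it shows that hydroxy and acetoxy cannot be told apart here: with the rest of the structure held the same, compound 3 reads alike with compound 2, so this change gives no handle on the read-out. Nothing at hand bears on why the two compounds read alike.

What the compounds shown leave open is whether any group on this oxygen can separate itself from hydroxy and acetoxy, for instance methyl, a longer acyl chain such as benzoyl, or a carbamate carrying an amine. From the compounds shown here alone, it also remains open whether a change elsewhere on the shared core would move the number at all, since all three compounds read alike.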